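Shortening the linker and trimming the aryl end: four dienones

This account rests on a few compounds, and the source may have more. Where it says the series, first, only, none or still open, it means among the compounds named here.

Compound 1 `COc1ccc(/C=C/C(=O)/C=C/c2ccc(OCc3cn(CCCCOc4cc(=O)oc5ccccc45)nn3)c(OC)c2)cc1OC`: 53%
Compound 2 `COc1cc(/C=C/C(=O)/C=C/c2ccccc2)ccc1OCc1cn(CCCCOc2cc(=O)oc3ccccc23)nn1`: 31%
Compound 3 `COc1ccc(/C=C/C(=O)/C=C/c2ccc(OCc3cn(CCOc4cc(=O)oc5ccccc45)nn3)c(OC)c2)cc1OC`: 80%

Three compounds were tested in a functional assay on COLO 205 cells (Homo sapiens) for inhibition, read by sulforhodamine B assay, with a stated time of 48 h, tested at 50 uM; a lower number here means less inhibition of growth, a higher number more inhibition of growth at the concentration tested. Compound 1 gives 53% in this assay, compound 2 gives 31%, and compound 3 gives 80%, the highest of the three; its steps to compound 1 and compound 2 both lie beyond the scatter.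

Compound 1 and compound 2 differ in one place phenyl in place of 3,4-dimethoxyphenyl on a double-bonded chain carbon bound to a double-bonded chain carbon and this change made a modest step of a number 22 percentage points lower from compound 1 to compound 2 (beyond the scatter).

Compound 4 `COc1cc(/C=C/C(=O)/C=C/c2ccccc2)ccc1OCc1cn(CCOc2cc(=O)oc3ccccc23)nn1` has not yet been measured. It stands to compound 3 as compound 2 stands to compound 1, the same change in the same place (phenyl in place of 3,4-dimethoxyphenyl on a double-bonded chain carbon bound to a double-bonded chain carbon). The difference between the core of compound 3 and that of compound 1 is not broken down here.

Going by the values given here, for compound 4 in this assay a step of the same kind is expected, a number 22 percentage points lower from compound 3 to compound 4 (beyond the scatter), because the same change gave a number 22 percentage points lower from compound 1 to compound 2 (beyond the scatter); with only one such pair in hand the expectation is loose. Compound 4 is therefore estimated at 58%, most likely between 40% and 75%.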

Compound 4, percent growth inhibition at one concentration: 54%
Estimate against measurement, compound 4: 4 percentage points above, within the range that was stated.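

In this assay, phenyl in place of 3,4-dimethoxyphenyl gave a number 26 percentage points lower from compound 3 to compound 4 (beyond the scatter), and this step agrees with the one seen earlier on the other core: the same change on two cores in this assay, a number 22 percentage points lower (beyond the scatter) from compound 1 to compound 2 and a number 26 percentage points lower (beyond the scatter) from compound 3 to compound 4, 4 percentage points apart, within the scatter of two such steps. The change therefore carried over between the core of compound 1 and the core of compound 3 in the same direction and at much the same size, so the two cores give one consistent reading of it. Going by these compounds alone, this rests on only two pairs at a single concentration, and it shows neither why growth inhibition falls with this change nor that the step would hold on any further core.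

The compounds shown leave open whether the two methoxy groups matter singly, since the 3,4-dimethoxyphenyl group leaves as a whole, and how a phenyl carrying an amine or a carboxylic acid would compare. Going by these compounds, it also remains open whether the same step would appear with a longer chain in the linker.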